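The source may report more compounds than this note shows. Statements on the series, on what has been measured and on what is new or still open speak of the compounds shown alone.

In an assay on tissue (M109 cells) for inhibition of Indoleamine 2,3-dioxygenase 1 (Mus musculus), with stated times of 2 h and 18 h (on this read-out lower numbers stand for stronger inhibition and higher numbers for weaker inhibition), compound 3 `C[C@@H](NC(=O)Nc1ccc(Cl)cc1)[C@H]1CC[C@@H](c2ccnc3ccc(F)cc32)CC1` gives 67 nM, which sits highest of the two numbers reported, although the nearest, compound 1 `C[C@@H](CNc1ccc(Cl)cc1)[C@H]1CC[C@@H](c2ccnc3ccc(F)cc32)CC1` at 62 nM, is within the scatter of it. Compound 2 `C[C@@H](NS(=O)(=O)c1ccc(Cl)cc1)[C@H]1CC[C@@H](c2ccnc3ccc(F)cc32)CC1` returns only a limit in this assay, > 1000 nM. For the measured compounds named here, the single measured step, an at least 14-fold lower number from compound 2 to compound 3 (1.17 log units; beyond the scatter), concerns the linker and keeps the chlorophenyl, so it bears only indirectly on compound 4 `C[C@@H](NC(=O)C12CCC(Cl)(CC1)CC2)[C@H]1CC[C@@H](c2ccnc3ccc(F)cc32)CC1`, which differs from compound 3 by a group of 9 heavy atoms (8 carbon, 1 chlorine; 2 six-membered non-aromatic rings of carbon only) in place of a group of 8 heavy atoms (6 carbon, 1 nitrogen, 1 chlorine; one six-membered aromatic ring of carbon only), on a carbonyl carbon. Going by the values given here, no measured step trades the aromatic ring for a non-aromatic one; compounds 1 and 3 only show that two linkers to the same chlorophenyl give numbers within the scatter. A small step is expected: a 1.2-fold higher number from compound 3 to compound 4 (0.08 log units; within the scatter). Compound 4 is expected at 80 nM in this assay, within 25 nM to 300 nM.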

Compound 4, half-maximal inhibitory concentration: 56 nM
For compound 4 the middle estimate is 1.4-fold (0.15 log units) above the measured one, within the range that was stated.
By their numbers in this assay, from the lowest: compounds 4, 1 and 3 (each within the scatter of the next). At a limit, above all of these: compound 2.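

In this assay the non-aromatic group in place of (4-chlorophenyl)amino, on a carbonyl carbon, gives a 1.2-fold lower number from compound 3 to compound 4 (0.08 log units; within the scatter), so this position does not tell the two groups apart. For this pair, neither the aromatic ring nor the hydrogen-bond donor of the departing group is needed to keep a number of this size. No measurement shown gives a reason for this result.

Open, on these data alone, is whether the chlorine on the non-aromatic group matters, which a hydrogen, methyl or nitrile in its place would show. Also open, as far as these compounds go, is how an amine or a carboxylic acid there would read.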